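The compounds below may be only part of what the source reports. "The series", "measured", "known", "first", "only" and "open" are said of these compounds alone.

Compound 2 `Cc1c(C(=O)N/N=C\c2cccc(O)c2)oc2cccc(O)c12` gives the highest number of the two measured in a functional assay on PC-3 cells (Homo sapiens) for inhibition (a lower number here means a stronger inhibitor, a higher number a weaker inhibitor), at 17600 nM; compound 1 `Cc1c(C(=O)N/N=C\c2ccccc2O)oc2cccc(O)c12` gives 8350 nM. For the measured compounds named here, the only measured step, a 2.1-fold higher number from compound 1 to compound 2 (0.32 log units; beyond the scatter), is the reverse of part of the change now considered. Compound 3 `Cc1c(C(=O)N/N=C\c2cc(Cl)ccc2O)oc2cccc(O)c12` differs from compound 2 in one place: 5-chloro-2-hydroxyphenyl in place of 3-hydroxyphenyl on a carbon with a double bond to nitrogen. Because a 2.1-fold higher number from compound 1 to compound 2 (0.32 log units; beyond the scatter) ran modestly upward, the return to a hydroxyl on the 2-position is expected to bring a modest step down in this assay of about a 2.5-fold lower number from compound 2 to compound 3 (0.40 log units; beyond the scatter), with the added chlorine unsupported by any measured comparison. Compound 3 is therefore expected to give about 7000 nM, within 2500 nM to 18000 nM.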

Compound 3, half-maximal inhibitory concentration: 3120 nM
Beside the measured number, compound 3's estimate is 2.2-fold (0.35 log units) above it; measured number inside the range.
By their numbers in this assay, from the lowest: compound 3; then compound 1; then compound 2.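

In this assay, chloro in place of hydrogen on an aromatic carbon gives a 2.7-fold lower number from compound 1 to compound 3 (0.43 log units; beyond the scatter), so the chlorine has a measured part in this change, separate from where the hydroxyl stands. The full replacement of 3-hydroxyphenyl by 5-chloro-2-hydroxyphenyl, which takes in both differences, gives a 5.6-fold lower number from compound 2 to compound 3 (0.75 log units; beyond the scatter). Nothing shown here accounts for either step.

Still open, as far as these compounds go, is whether bromo or methoxy in place of the chloro would give a similar step. Also open, from the compounds shown here alone, is how an amine in place of the hydroxyl of 5-chloro-2-hydroxyphenyl would read in this assay.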